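From 4-Methylphenyl to 3-Methoxyphenyl on the Shared Core

The source may hold more compounds than are shown below. What is called first, only, known or untested is meant among the compounds shown, and "the series" means these compounds.

Compound 1 `C=C(Br)C(=O)Nc1cccc(-c2cn3nc(-c4ccc(C)cc4)sc3n2)c1` is the stronger of the two measured compounds in a functional assay on HeLa cells (Homo sapiens) for inhibition, read by cell counting, with a stated time of 4 days (a higher number here means a weaker inhibitor, a lower number a stronger inhibitor), where compound 1 gives 2000 nM. Compound 2 `Nc1cccc(-c2cn3c(-c4ccccc4)csc3n2)c1`, built on a different core, gives 60000 nM in this assay, a weaker result that lies beyond the scatter of the method. Within the data shown here, no pair of measured compounds differing in one place is available, so the weight of a single change on the shared core cannot be read from the numbers at hand.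

Compound 3 `C=C(Br)C(=O)Nc1cccc(-c2cn3nc(-c4cccc(OC)c4)sc3n2)c1` differs from compound 1 in one place: 3-methoxyphenyl in place of 4-methylphenyl on an aromatic carbon. Among the measured compounds shown here, with no measured single step to lean on, the size of this step is uncertain; a change of this kind is expected to move the result little, most likely within the scatter, with a slight lean toward a weaker inhibitor. Compound 3 is therefore estimated to give 3000 nM in this assay, within a range of 1000 nM to 9000 nM. The expected step is a 1.5-fold higher number from compound 1 to compound 3 (0.18 log units; within the scatter).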

Compound 3, half-maximal inhibitory concentration: 1100 nM
Compound 3: middle estimate off by 2.7-fold (0.44 log units), on the high side; measured number inside the range.
By their numbers in this assay, from the lowest: compounds 3 and 1 (each within the scatter of the next); then compound 2.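

In this assay, among these compounds, putting 3-methoxyphenyl in place of 4-methylphenyl on the aromatic carbon next to the ring nitrogen and next to the ring sulfur gives a 1.8-fold lower number from compound 1 to compound 3 (0.26 log units; within the scatter), the first single step on the shared core that can be read. At this position, then, a swap that takes the group from 7 heavy atoms to 8, adds an oxygen and goes from 0 hydrogen-bond acceptors to 1 leaves the two compounds within the scatter of each other, so for this pair the assay does not tell the two groups apart. Nothing measured here explains why the two compounds read alike.

The step changes both the kind of group on the phenyl ring and where it sits, so compound 1 and compound 3 alone cannot separate these two changes, which a 3-methylphenyl or a 4-methoxyphenyl group would begin to do. From the compounds shown here alone, it also remains open whether this position would tolerate something further from these two groups, such as an amine or a carboxylic acid on the phenyl ring, or a longer chain in place of the ring.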